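The source may report more compounds than this note shows. Statements on the series, on what has been measured and on what is new or still open speak of the compounds shown alone.

Of the compounds shown here, three built on one shared core have been tested in a functional assay on the whole organism (strain Kunming) for inhibition, with Mus musculus as the target, with a stated time of 1 h, at a dose of 40 mg/kg by the oral route; a lower number here means less inhibition, a higher number more inhibition at the dose given (going by the name of the read-out). Compound 1, `O=C(/C=C/c1ccccc1)c1ccc(N2CCN(S(=O)(=O)c3ccc(Br)cc3)CC2)cc1`, gives 47.4% in this assay. Compound 2, `COc1ccc(S(=O)(=O)N2CCN(c3ccc(C(=O)/C=C/c4ccccc4)cc3)CC2)cc1`, gives 45.2% in this assay. Compound 3, `COc1ccc(/C=C/C(=O)c2ccc(N3CCN(S(=O)(=O)c4ccc(Br)cc4)CC3)cc2)cc1OC`, gives 75.5% in this assay, the highest of the three numbers; its steps to the other two compounds are both beyond the usual scatter.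

Two structural relationships run through the set. Compound 2 differs from compound 1 by methoxy in place of bromo on an aromatic carbon, and this change brought a number 2.2 percentage points lower from compound 1 to compound 2 (within the scatter). The core of compound 3 differs from the core of compound 1 by 3,4-dimethoxyphenyl in place of phenyl on a double-bonded chain carbon bound to a double-bonded chain carbon, which brought a number 28.1 percentage points higher from compound 1 to compound 3 (beyond the scatter).

Compound 4, `COc1ccc(S(=O)(=O)N2CCN(c3ccc(C(=O)/C=C/c4ccc(OC)c(OC)c4)cc3)CC2)cc1`, remains to be measured in this assay. It differs from compound 3 by methoxy in place of bromo on an aromatic carbon, the same change that separates compound 2 from compound 1, made at the same place on the ring. Whatever compound 4 turns out to give, the only guide is the earlier pair: the expected step is a number 2.5 percentage points lower from compound 3 to compound 4 (within the scatter), because the identical change earlier gave a number 2.2 percentage points lower from compound 1 to compound 2 (within the scatter), a move that lay within the scatter. On that basis compound 4 is estimated at 73% in this assay. The range expected for compound 4 runs from 60% to 85%, reflecting both the small earlier step and the ordinary spread of repeated measurements of this kind.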

Compound 4, a percentage reported as inhibition, in the whole organism at one dose (the size of the read-out at that dose, not a potency): 64.1%
Compound 4: middle estimate off by 8.9 percentage points, on the high side; low and high end bracket the measured number.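

In this assay, methoxy in place of bromo on the dimethoxy-bearing core brought a number 11.4 percentage points lower from compound 3 to compound 4 (beyond the scatter), and the step carried over from the core of compound 1 to that of compound 3 without a gap that exceeds the scatter: the same change on two cores in this assay, a number 2.2 percentage points lower (within the scatter) from compound 1 to compound 2 and a number 11.4 percentage points lower (beyond the scatter) from compound 3 to compound 4, 9.2 percentage points apart, within the scatter of two such steps. The 3,4-dimethoxyphenyl in place of phenyl brought a number 18.9 percentage points higher from compound 2 to compound 4 (beyond the scatter), so this change went the same way on the bromo and the methoxy cores, again with no gap beyond the scatter: the same change on two cores in this assay, a number 28.1 percentage points higher (beyond the scatter) from compound 1 to compound 3 and a number 18.9 percentage points higher (beyond the scatter) from compound 2 to compound 4, 9.2 percentage points apart, within the scatter of two such steps. Within the data shown here, this does not show that the bromo-to-methoxy change has one fixed size, since only one of its two steps lies beyond the scatter and two pairs cannot tell a small dependence on the core from ordinary spread.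

The compounds shown carry only bromo or methoxy on the sulfonyl-bound ring and only phenyl or 3,4-dimethoxyphenyl on the chain, so it stays open how a chloro, a nitrile or an amine would behave at the first place, or a single methoxy or a hydroxy at the second. On these data alone, it also stays open whether either change would carry over to a core in which the sulfonyl is replaced by a carbonyl.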